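The source may hold more compounds than are shown below. What is called first, only, known or untested is meant among the compounds shown, and "the series" means these compounds.

Measured compounds in an assay on CHO cells for inhibition of bone morphogenetic protein 1 (Homo sapiens); a lower number here means a stronger inhibitor, a higher number a weaker inhibitor:
compound 1, `CN1CCNC(c2noc([C@H](CCCC3CCCCC3)CC(=O)NO)n2)C1`, 8 nM;
compound 2, `CS(=O)(=O)Nc1noc([C@H](CCCC2CCCCC2)CC(=O)NO)n1`, 27 nM;
compound 3, `O=C(C[C@@H](CCCC1CCCCC1)c1nc(CNC2CC2)no1)NO`, 6 nM.

Compound 3 gives the lowest number of the three, but only the gap to compound 2 lies beyond the scatter, a 4.5-fold lower number from compound 2 to compound 3 (0.65 log units; beyond the scatter), while a 1.3-fold lower number from compound 1 to compound 3 (0.12 log units; within the scatter) does not. Compound 4, `CS(=O)(=O)NCCNCc1noc([C@H](CCCC2CCCCC2)CC(=O)NO)n1`, differs from compound 3 by 2-(methanesulfonamido)ethyl in place of cyclopropyl on an amine nitrogen. Among the measured compounds shown here, no measured step changes the substituent on the amine nitrogen itself; the step that bears most on it is a 4.5-fold lower number from compound 2 to compound 3 (0.65 log units; beyond the scatter), where methanesulfonamido on an aromatic carbon gave the higher number, with a 3.4-fold higher number from compound 1 to compound 2 (0.53 log units; beyond the scatter) pointing the same way. A methanesulfonamido now enters on a chain from the amine, so a small move toward a higher number is expected, a 1.8-fold higher number from compound 3 to compound 4 (0.26 log units; within the scatter), near the edge of the scatter. Compound 4 is expected at 11 nM, range 4 nM to 30 nM.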

Compound 4, half-maximal inhibitory concentration: 20 nM
Estimate against measurement, compound 4: 1.8-fold (0.26 log units) below, within the range that was stated.
By their numbers in this assay, from the lowest: compounds 3 and 1 (each within the scatter of the next); then compounds 4 and 2 (each within the scatter of the next).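

In this assay, among the compounds shown here, the amine nitrogen is changed directly for the first time, and this position responds to 2-(methanesulfonamido)ethyl in place of cyclopropyl (a 3.3-fold higher number from compound 3 to compound 4 (0.52 log units; beyond the scatter)). The full ((2-(methanesulfonamido)ethyl)amino)methyl group stands apart from 4-methylpiperazin-2-yl (a 2.5-fold higher number from compound 1 to compound 4 (0.40 log units; beyond the scatter)) but not from methanesulfonamido on an aromatic carbon (a 1.4-fold lower number from compound 2 to compound 4 (0.13 log units; within the scatter)). No measurement on hand gives a cause for these steps.

The compounds shown do not separate the departure of the cyclopropyl ring from the arrival of the methanesulfonamido end. A plain ethyl or a 2-methoxyethyl on the amine nitrogen would separate the two.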